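The compounds below may be only part of what the source reports. "The series", "measured", "known", "first", "only" and "open" are said of these compounds alone.

Compound 1 `COc1ccc(C(=O)CSC(=S)Nc2cc(OC)c(OC)c(OC)c2)cc1` gives 18.6 ug/mL in a functional assay on MCF7 cells (Homo sapiens) for cytotoxicity, read by MTT assay, with a stated time of 48 h; on this read-out higher numbers stand for weaker inhibition and lower numbers for stronger inhibition.
Compound 2 `COc1cc(-n2c(-c3ccc(Br)cc3)csc2=S)cc(OC)c1OC` gives only a limit, > 100 ug/mL, in this assay.
Compound 3 `COc1cc(-n2c(-c3ccc(Cl)cc3)csc2=S)cc(OC)c1OC` also gives only a limit, > 100 ug/mL, in this assay.

Compound 2 stands at the limit of > 100 ug/mL in this assay, at which 2 of the 3 values shown sit; its number is not known, only that it lies past what the assay reports. For the measured compounds named here, the single measured step that touches it, a step that the two limits leave unreadable from compound 2 to compound 3, is therefore unreadable, because the limit of > 100 ug/mL in this assay, at which 2 of the 3 values shown sit, holds both ends of it. Compound 4 `COc1cc(-n2c(-c3ccc(O)cc3)csc2=S)cc(OC)c1OC` differs from compound 2 by hydroxy in place of bromo on an aromatic carbon. Going by the values given here, no measured step exchanges a bromo for a hydroxy, so no size can be read from the data for this change, and the step from compound 2 to compound 3 gives no guidance either. What remains is that the shared core of compound 2 and compound 3 has twice given only a limit, whereas compound 1, built differently, gives a readable number. Compound 4 is therefore expected to stay weak, estimated at 70 ug/mL, between 20 ug/mL and 150 ug/mL. The step of an at least 1.4-fold lower number from compound 2 to compound 4 (0.15 log units; that floor lies within the scatter) is thus expected to be small or not readable, with a fair chance that compound 4 again reaches only the limit.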

Compound 4, half-maximal inhibitory concentration: 35.1 ug/mL
Compound 4: the middle estimate sits 2.0-fold (0.30 log units) above what was measured; low and high end bracket the measured number.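

In this assay, the aromatic carbon para to a large group proves sensitive to what it carries: hydroxy in place of bromo gives an at least 2.8-fold lower number from compound 2 to compound 4 (0.45 log units; beyond the scatter), and hydroxy in place of chloro gives an at least 2.8-fold lower number from compound 3 to compound 4 (0.45 log units; beyond the scatter). For the compounds shown here, the step between the two halogen compounds cannot be read, so these steps are the first readable evidence that a change at this position can move the shared core to a measurable number. Both sizes are only floors, because compound 2 and compound 3 each give a limit rather than a number: the limit of > 100 ug/mL in this assay, at which 2 of the 4 values shown sit.

From the compounds shown here alone, whether this shift is particular to hydroxy, or would also appear with an amine or a carboxylic acid on the same carbon, remains open. The compounds shown also leave open how hydroxy would act at this position on the core of compound 1.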